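From 4-methylbenzyl to 3-fluorobenzyl: a small expected step

The source may report more compounds than this note shows. Statements on the series, on what has been measured and on what is new or still open speak of the compounds shown alone.

In a physicochemical assay for solubility (a lower number here means a less soluble compound, a higher number a more soluble compound), compound 1 (`CNC(=O)c1cc(C(=O)NC2CC2)cn(Cc2ccc(OC)cc2)c1=O`) reads >= 143 ug/mL as a limit of the assay and not a number. For the measured compounds named here, compound 2 (`CNC(=O)c1cc(C(=O)NC2CC2)cn(Cc2ccc(C)cc2)c1=O`) gives 24 ug/mL as the only true number so far. Going by the values given here, the one measured step of an at least 5.9-fold lower number from compound 1 to compound 2 (0.77 log units; beyond the scatter) lies beyond the scatter, but it put methyl in place of methoxy on an aromatic carbon, so it is only a weak guide here. Compound 3 (`CNC(=O)c1cc(C(=O)NC2CC2)cn(Cc2cccc(F)c2)c1=O`) instead has 3-fluorophenyl in place of 4-methylphenyl on a saturated chain carbon bound to an aromatic nitrogen. The expected step is a 1.3-fold higher number from compound 2 to compound 3 (0.10 log units; within the scatter) in this assay with no move beyond the scatter. Compound 3 is estimated at 30 ug/mL and expected to fall from 10 ug/mL to 90 ug/mL in most measurements.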

Compound 3, solubility: >= 133 ug/mL
Compound 3: no number, only a limit; the forecaster's own chance of this, stated with the estimate: 10%; middle value at least 4.4-fold (0.64 log units) away from the limit.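

In this assay compound 3 gives >= 133 ug/mL, which is a limit of the assay and not a number. Exchanging 4-methylphenyl for 3-fluorophenyl, groups of 7 heavy atoms each, gives an at least 5.5-fold higher number from compound 2 to compound 3 (0.74 log units; beyond the scatter), so even a swap of this size at this position can move the read-out beyond the scatter. Compound 2 now has the lowest reading of the three, with its steps to both other compounds beyond the scatter.

On these data alone, the step from compound 1 to compound 3 cannot be read, so their order stays open. What an amine or a carboxylic acid on this phenyl ring would do is also unknown.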